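The source may hold more compounds than are shown below. What is called first, only, known or untested is meant among the compounds shown, and "the series" means these compounds.

Values in an ADME assay on L6 cells (Rattus norvegicus) for cytotoxicity, read by resazurin assay, with a stated time of 72 h; on this read-out higher numbers stand for weaker inhibition and lower numbers for stronger inhibition:
- compound 1 `Cc1ccc(C(=O)NC(=O)c2ccccc2O)cc1`: 46 ug/mL
- compound 2 `CCCCOc1ccc(C(=O)NC(=O)c2ccccc2O)cc1`: 13 ug/mL
- compound 3 `COC(=O)CCC(=O)Nc1ccc(C(=O)NC(=O)c2ccccc2O)cc1`: > 50 ug/mL (a limit)

Compound 3 has no number, only the limit > 50 ug/mL. Compound 4 `O=C(CCCCCCC(=O)Nc1ccc(C(=O)NC(=O)c2ccccc2O)cc1)NO` carries 4-(hydroxycarbamoyl)butyl in place of methoxycarbonyl on a saturated chain carbon, two bonds along the chain from a carbonyl carbon.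

Going by the values given here, no measured step contains this group, so the guidance is indirect. The nearest steps change the substituent on the shared core: a 3.5-fold lower number from compound 1 to compound 2 (0.55 log units; beyond the scatter) and an at least 3.8-fold higher number from compound 2 to compound 3 (0.58 log units; beyond the scatter). Both are modest, though the second is only a floor. A lower number of comparable or somewhat larger size is expected in this assay. The expected change is an at least 5.0-fold lower number from compound 3 to compound 4 (0.69 log units; beyond the scatter). The estimated value for compound 4 is 10 ug/mL, with an expected range of 2 ug/mL to 40 ug/mL.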

Compound 4, half-maximal inhibitory concentration: > 100 ug/mL
Compound 4 ended at the assay's limit; the forecaster's own chance of this, stated with the estimate: 10%; at least 10-fold (1.00 log units) between middle value and limit.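

In this assay compound 3 gives the limit > 50 ug/mL. Compound 4 gives the limit > 100 ug/mL. Going by these compounds alone, with two limits, no step between compound 3 and compound 4 can be read. The compounds shown leave open where either one's actual value lies.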